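The source may report more compounds than this note shows. Statements on the series, on what has been measured and on what is new or still open speak of the compounds shown alone.

Compound 1 `COc1ccc(C2=Cc3ccc([N+](=O)[O-])cc3C(CC(C)=O)N2c2ccc(C#N)cc2)cc1` is examined in an ADME assay on TZM cells (Homo sapiens) for cytotoxicity, read by CellTiter-Glo, with a stated time of 48 h (on this read-out higher numbers stand for lower toxicity in this test and lower numbers for higher toxicity in this test), where compound 1 gives 15400 nM. Compound 2 `COc1ccc(C2=Cc3ccc([N+](=O)[O-])cc3C(CC(C)=O)N2c2ccc(O)cc2)cc1` carries hydroxy in place of cyano on an aromatic carbon and in this assay compound 2 gives 23500 nM, a step described as a 1.5-fold higher number from compound 1 to compound 2 (0.18 log units; within the scatter). Compound 3 `COc1ccc(C2=Cc3ccc(F)cc3C(CC(=O)C(C)O)N2c2ccc(C#N)cc2)cc1` rests on a different core; the difference between the two cores is not broken down here. In this assay compound 3 gives 24100 nM. Among the compounds with values here, compound 4 `COc1ccc(C2=Cc3ccc(F)cc3C(CC(=O)C(C)O)N2c2ccc(O)cc2)cc1` is not yet measured and differs from compound 3 by hydroxy in place of cyano on an aromatic carbon, the same change as the one from compound 1 to compound 2. The step expected in this assay is a 1.2-fold higher number from compound 3 to compound 4 (0.10 log units; within the scatter), which rests on the earlier step of a 1.5-fold higher number from compound 1 to compound 2 (0.18 log units; within the scatter). Compound 4 is therefore estimated at 30000 nM, with a range from 15000 nM to 60000 nM.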

Compound 4, half-maximal cytotoxic concentration: 50900 nM
The estimate for compound 4 lay 1.7-fold (0.23 log units) below the measured number; the measured number falls inside the stated range.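

In this assay, replacing 4-cyanophenyl with 4-hydroxyphenyl on the second core gives a 2.1-fold higher number from compound 3 to compound 4 (0.32 log units; beyond the scatter). The direction matches that on the first core, and the two steps do not measurably differ: the same change on two cores in this assay, a 1.5-fold higher number (0.18 log units; within the scatter) from compound 1 to compound 2 and a 2.1-fold higher number (0.32 log units; beyond the scatter) from compound 3 to compound 4, 1.4-fold (0.14 log units) apart, within the scatter of two such steps. The change therefore carried over to the core of compound 3 with a comparable size, but two pairs, one of them within the scatter, do not establish a rule for other cores in this series.

The compounds shown hold only cyano or hydroxy at this place, so whether an amine or a carboxylic acid there would behave alike stays open. The nitro and fluoro groups also change together with the side chain between the cores, leaving their separate contributions unresolved.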